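Swapping Chloro for Iodo on a Urea Scaffold

The compounds below may be only part of what the source reports. "The series", "measured", "known", "first", "only" and "open" are said of these compounds alone.

Measured so far:
In an ADME assay on the whole organism with Oryza sativa as the target, tested at 0.1 uM (a lower number here means a stronger effect, a higher number a weaker effect of the compound at the concentration tested), compound 1, `CC(=O)c1ccccc1NC(=O)N[C@@H](C)c1ccccc1`, gives 100%.
In this assay compound 2, `C[C@H](NC(=O)Nc1ccccc1Cl)c1ccccc1`, gives 99%.

On the two numbers shown, compound 2 stands at the lowest of them, with compound 1 as its only neighbour; the step of a number 1 percentage points lower from compound 1 to compound 2 (within the scatter) lies within the scatter, so the two compounds are not told apart by these measurements. Both sit at the top of the scale, meaning the compounds had essentially no effect at the concentration tested.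

Compound 3, `C[C@H](NC(=O)Nc1ccccc1I)c1ccccc1`, has not yet been measured. It differs from compound 2 in one place: iodo in place of chloro on an aromatic carbon. Among the compounds with values here, only one measured step bears on this change, namely a number 1 percentage points lower from compound 1 to compound 2 (within the scatter), which also swapped one group at that aromatic carbon and left the number where it was. Within the data shown here, with one within-scatter step as the only guide, and both measured numbers at the top of the scale, no step beyond the scatter is expected in this assay for compound 3. The value expected for compound 3 is 97%, within a range from 85% to 100%, which amounts to an expected step of a number 2 percentage points lower from compound 2 to compound 3 (within the scatter).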

Compound 3, a percentage reported as activity, at one concentration (the size of the read-out at that concentration, not a potency): 99%
Beside the measured number, compound 3's estimate is 2 percentage points below it; the range from low to high includes it.
By their numbers in this assay, from the lowest: compounds 2, 3 and 1 (each within the scatter of the next).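

In this assay, the swap of iodo for chloro on the aromatic carbon ortho to a large group gives no change at the digits printed from compound 2 to compound 3 (within the scatter), while the swap of iodo for acetyl at the same carbon gives a number 1 percentage points lower from compound 1 to compound 3 (within the scatter) in that measurement. Within the data shown here, three groups at this one position, acetyl, chloro and iodo, now cannot be told apart, whereas the earlier compounds offered only a single comparison, and the two halogens, a smaller and a larger atom of the same family, add a second swap that leaves the read-out at the top of the scale, where the compounds have essentially no effect at the concentration tested. Nothing measured on these compounds offers an explanation for why the three read alike.

On these data alone, whether a group of a different kind on this carbon, such as an amine or a carboxylic acid, would bring the number down remains open. Also open, as far as these compounds go, is whether compound 1, compound 2 and compound 3 would separate at a higher concentration, where a real effect might first appear.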